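Acylating the ring amine of compound 1

The source may report more compounds than this note shows. Statements on the series, on what has been measured and on what is new or still open speak of the compounds shown alone.

Measured so far in a functional assay on U-87MG ATCC cells (Homo sapiens) for antiproliferative activity; a lower number here means a stronger inhibitor, a higher number a weaker inhibitor:
- compound 1 `Cc1c2c(n3c1CCNC[C@@H](C)[C@H](C)Nc1cc-3ccc1C(N)=O)CC(C)(C)CC2=O`: 40 nM
- compound 2 `Cc1c2c(n3c1CCCN(C(=O)CO)[C@@H](C)[C@H](C)Nc1cc-3ccc1C(N)=O)CC(C)(C)CC2=O`: 111 nM

Compound 1 holds the lower number of the two, and the gap up to compound 2 lies beyond the usual scatter of this assay. It is therefore the stronger inhibitor of this small set and the reference point for the next step.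

The next compound to be tested is compound 3 `Cc1c2c(n3c1CCN(C(=O)[C@@H](N)C(C)C)C[C@@H](C)[C@H](C)Nc1cc-3ccc1C(N)=O)CC(C)(C)CC2=O`. It is derived from compound 1 by placing (1-amino-2-methylpropyl)carbonyl in place of hydrogen on an amine nitrogen in a ring.

For the measured compounds named here, no measured pair isolates this change, so the size of the step cannot be read directly. Going by the values given here, the only measured compound with an acylated ring nitrogen is compound 2, at 111 nM, although its nitrogen sits elsewhere in the ring and its acyl group is different. A moderate loss is expected in this assay, meaning a higher number than for compound 1, though a step within the scatter remains possible. The expected step is a 2.8-fold higher number from compound 1 to compound 3 (0.44 log units; beyond the scatter). The estimated value for compound 3 is 110 nM, with an expected range of 35 nM to 350 nM.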

Compound 3, half-maximal inhibitory concentration: 48 nM
Beside the measured number, compound 3's estimate is 2.3-fold (0.36 log units) above it; low and high end bracket the measured number.
By their numbers in this assay, from the lowest: compounds 1 and 3 (each within the scatter of the next); then compound 2.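

Replacing hydrogen on the amine nitrogen in the ring with (1-amino-2-methylpropyl)carbonyl gives, in this assay, a 1.2-fold higher number from compound 1 to compound 3 (0.08 log units; within the scatter). For the compounds shown here, this is the first directly measured step at this position, and it shows that the nitrogen can carry an acyl group of 7 heavy atoms, with a free amine and a defined stereocentre, without a change beyond the scatter; the hydrogen on this nitrogen is therefore not required for antiproliferative activity in this pair. Nothing available accounts for this result.

Going by these compounds, with a single pair at this nitrogen, it remains open which part of the acyl group matters: the amine, the branched side chain or the configuration at its stereocentre. An acetyl group, an acyl group ending in a carboxylic acid, or the same (1-amino-2-methylpropyl)carbonyl group with the opposite configuration at that stereocentre would show whether this tolerance extends beyond compound 3.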